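The compounds below may be only part of what the source reports. "The series", "measured", "known", "first", "only" and "open" are said of these compounds alone.

Working notes on the benzylsulfanyl series

The shared core is carried by compound 3 `COc1ccc(C2N=C(SCc3ccc(Cl)cc3)NC(C)=C2C(=O)Nc2ccc(F)cc2)cc1OC` and by its two measured relatives, compound 1 `COc1ccc(C2N=C(SCc3ccccc3Cl)NC(C)=C2C(=O)Nc2ccc(F)cc2)cc1OC` and compound 2 `COc1ccc(C2N=C(SCc3cccc(Cl)c3)NC(C)=C2C(=O)Nc2ccc(F)cc2)cc1OC`. In a functional assay on the whole organism (artery, strain albino) with Rattus norvegicus as the target, with a stated time of 120 min, at a dose of 10 mg/kg by the oral route (on this read-out higher numbers stand for more inhibition at the one dose given (going by the name of the read-out) and lower numbers for less inhibition), compound 1 gives 17%, compound 2 gives 10.8% and compound 3 gives 15.5%. On the raw numbers compound 3 lies between the other two, but none of the three is separated from another by more than the scatter: a number 1.5 percentage points lower from compound 1 to compound 3 (within the scatter), a number 4.7 percentage points higher from compound 2 to compound 3 (within the scatter) and a number 6.2 percentage points lower from compound 1 to compound 2 (within the scatter). Moving the chloro around the benzyl ring therefore leaves the read-out unchanged within what repeated measurements would show.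

Compound 4 `COc1ccc(C2N=C(SCc3ccc(F)cc3)NC(C)=C2C(=O)Nc2ccc(F)cc2)cc1OC` keeps the core and differs from compound 3 in one place: fluoro in place of chloro on an aromatic carbon. For the measured compounds named here, no measured pair in the set exchanges one halogen for another; the three known steps all concern the position of chloro and all fall within the scatter. With nothing in the data pointing either way, the expected change for compound 4 in this assay is none beyond the scatter, a number 0.5 percentage points lower from compound 3 to compound 4 (within the scatter). The expected value for compound 4 is therefore 15%, with a range from 5% to 25%.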

Compound 4, a percentage reported as inhibition, in the whole organism at one dose (the size of the read-out at that dose, not a potency): 15.5%
Estimate against measurement, compound 4: 0.5 percentage points below; low and high end bracket the measured number.
By their numbers in this assay, from the lowest: compounds 2, 3, 4 and 1 (each within the scatter of the next).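

In this assay, for the compounds shown here, the exchange of chloro for fluoro on the aromatic carbon para to a large group gives no change at the digits printed from compound 3 to compound 4 (within the scatter) and is the first step to alter the identity of the halogen rather than its position on the benzyl ring. The 4-fluorobenzyl compound also stays within the scatter of both other chloro compounds, with a number 4.7 percentage points higher from compound 2 to compound 4 (within the scatter) and a number 1.5 percentage points lower from compound 1 to compound 4 (within the scatter), so all four compounds now form one group on this read-out, and neither the position of chloro nor this choice of halogen at the 4-position separates any pair. No available measurement bears on the reason for this result.

The compounds shown carry only chloro or fluoro on the benzyl ring, so it remains open whether an amine, a carboxylic acid or a methoxy group at this position, or a longer chain in place of the benzyl group on the sulfur, would give a step beyond the scatter. With one oral dose and one time point, the read-out also leaves open whether these compounds would separate at other doses.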